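Swapping a Branched Alkyl for a Pyrrolidine Side Chain

The source may report more compounds than this note shows. Statements on the series, on what has been measured and on what is new or still open speak of the compounds shown alone.

Of the compounds shown here, three sharing one core have been measured in a functional assay on BT-474 cells (Homo sapiens) for inhibition; a lower number here means a stronger inhibitor, a higher number a weaker inhibitor. Compound 1, `COc1c(C)cnc(CN2CC(=O)N(CC(C)C)c3c(Cl)nc(N)nc32)c1C`, gives 20 nM. Compound 3, `COc1c(C)cnc(CN2CC(OC3CCCC3)=Nc3c(Cl)nc(N)nc32)c1C`, gives 10 nM, a value that differs from compound 1 only within the usual scatter, so no order between the two can be read. Compound 2, `COc1c(C)cnc(CN2c3nc(N)nc(Cl)c3NC(=O)[C@@H]2CC(C)C)c1C`, gives 490 nM, which places it clearly beyond the scatter on the weaker side of compound 1. Compound 1 thus holds the second highest of the three numbers, close to compound 3 and far from compound 2.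

Compound 4, `COc1c(C)cnc(CN2CC(=O)N(CCN3CCCC3)c3c(Cl)nc(N)nc32)c1C`, has not yet been measured. It differs from compound 1 by a single change: (pyrrolidin-1-yl)methyl in place of isopropyl on a saturated chain carbon bound to an amide-type nitrogen in a ring. Cut one bond further out, the same change reads isobutyl to 2-(pyrrolidin-1-yl)ethyl.

Among the measured compounds shown here, no measured pair shows this change, so the size of the step is unknown. The expectation is that the step from compound 1 to compound 4 stays small, with the number for compound 4 expected somewhat higher than that of compound 1 but not beyond the scatter, at a 1.5-fold higher number from compound 1 to compound 4 (0.18 log units; within the scatter). Compound 4 is therefore estimated at 30 nM, with a range from 8 nM to 120 nM.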

Compound 4, half-maximal inhibitory concentration: 520 nM
For compound 4 the middle estimate is 17-fold (1.24 log units) below the measured one; measured number outside the range, above it.
By their numbers in this assay, from the lowest: compounds 3 and 1 (each within the scatter of the next); then compounds 2 and 4 (each within the scatter of the next).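

This position does not tolerate every side chain: exchanging isobutyl for 2-(pyrrolidin-1-yl)ethyl on the amide-type nitrogen of the shared core gives a 26-fold higher number from compound 1 to compound 4 (1.41 log units; beyond the scatter) in this assay, a large step and the only single change that can be read among these compounds. Seen as (pyrrolidin-1-yl)methyl in place of isopropyl, the change replaces 3 heavy atoms, all carbon, with 6 heavy atoms, including a nitrogen and a five-membered ring, so size, ring and nitrogen all change together in this one step. No measurement shown here explains why the number rises.

From the compounds shown here alone, it stays open whether the higher number goes with the ring nitrogen or simply with the larger group, and a 2-cyclopentylethyl chain, which keeps a five-membered ring but has only carbon in it, would help separate the two. Also open, going by these compounds, is how much of the effect depends on the ring itself, a question that an open-chain 2-(diethylamino)ethyl group would address.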